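From Methoxyphenyl to Methoxypyridine: Predicting Compound 4

The source may hold more compounds than are shown below. What is called first, only, known or untested is meant among the compounds shown, and "the series" means these compounds.

Compound 1 `C=CC(=O)Nc1cccc(Oc2nc(Nc3ccc(OC)cc3)nc3c2CSCC3)c1` carries a vinyl group on its carbonyl carbon, and in a functional assay on A549 cells (Homo sapiens) for antiproliferative activity, read by MTT assay, with a stated time of 72 h (on this read-out lower numbers stand for stronger inhibition and higher numbers for weaker inhibition), compound 1 gives 4220 nM. Compound 2 `CC/C=C/C(=O)Nc1cccc(Oc2nc(Nc3ccc(OC)cc3)nc3c2CSCC3)c1` has but-1-en-1-yl in that place and gives 20100 nM. Compound 3 `CCC/C=C/C(=O)Nc1cccc(Oc2nc(Nc3ccc(OC)cc3)nc3c2CSCC3)c1` has pent-1-en-1-yl there and gives 11900 nM. Both longer chains raise the number beyond the scatter, with a 4.8-fold higher number from compound 1 to compound 2 (0.68 log units; beyond the scatter) and a 2.8-fold higher number from compound 1 to compound 3 (0.45 log units; beyond the scatter). The remaining step, a 1.7-fold lower number from compound 2 to compound 3 (0.23 log units; within the scatter), stays within the scatter. Compound 3 therefore stands level with compound 2, and both sit above compound 1.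

Compound 4 `CCC/C=C/C(=O)Nc1cccc(Oc2nc(Nc3ccc(OC)nc3)nc3c2CSCC3)c1` keeps the pent-1-en-1-yl chain and changes a different part of the molecule: 6-methoxypyridin-3-yl in place of 4-methoxyphenyl on a nitrogen on an aromatic ring. In words, 6-methoxypyridin-3-yl takes the place of 4-methoxyphenyl on a nitrogen on an aromatic ring. For the measured compounds named here, all the measured steps concern the chain on the carbonyl carbon, so none of them tests this swap or gives it a direction. They show only modest movement for a change in one place. In this assay, the value of compound 3, 11900 nM, is thus the best anchor, and no shift beyond the scatter is expected: a 1.1-fold lower number from compound 3 to compound 4 (0.03 log units; within the scatter). The estimate for compound 4 is 11000 nM, with an expected range of 4000 nM to 30000 nM.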

Compound 4, half-maximal inhibitory concentration: 10800 nM
The estimate for compound 4 lay 1.0-fold (0.01 log units) above the measured number; the measured number falls inside the stated range.
By their numbers in this assay, from the lowest: compound 1; then compounds 4, 3 and 2 (each within the scatter of the next).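

The swap to 6-methoxypyridin-3-yl is the only change shown away from the chain on the carbonyl carbon, and in this assay it gives a 1.1-fold lower number from compound 3 to compound 4 (0.04 log units; within the scatter) and so stays within the scatter. The two groups have the same count of heavy atoms, but a ring nitrogen replaces a ring carbon and the count of hydrogen-bond acceptors rises, so for this pair that difference on the amino nitrogen leaves the number unmoved, whereas the chain changes from compound 1 to compound 2 and from compound 1 to compound 3 went beyond the scatter. Nothing available explains this flat result, which stands as an observation only.

On these data alone, this single pair rests on the pent-1-en-1-yl chain, so it remains open whether the same swap would also leave the number unmoved in compound 1, where the vinyl group gives the lowest number of the series. It also leaves open what a larger change at this place would do, such as a morpholine or a carboxylic acid on the ring in place of the methoxy group.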